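From Propargyl to Carbamoylmethyl on a Shared Core

The source may hold more compounds than are shown below. What is called first, only, known or untested is meant among the compounds shown, and "the series" means these compounds.

Of the compounds shown here, two have been measured in a functional assay on the whole organism with Rattus norvegicus as the target; a lower number here means that less compound is needed, a higher number that more compound is needed for the effect. Compound 1 `Nc1nc2cccc(OC(F)(F)F)c2s1` returned only a limit, > 10 mg/kg. Among the compounds with values here, compound 2 `C#CCn1c(=N)sc2cc(OC(F)(F)F)ccc21` gave 4 mg/kg, the only actual number so far. The next compound, compound 3 `N=c1sc2cc(OC(F)(F)F)ccc2n1CC(N)=O`, keeps the core of compound 2 and alters its side chain carbamoyl in place of ethynyl on a saturated chain carbon bound to an aromatic nitrogen, or propargyl to carbamoylmethyl when cut one bond further out. Within the data shown here, no measured pair shows what this change does, so the value of compound 2 at 4 mg/kg is the only anchor. A modest shift toward a higher dose in this assay is expected, with the estimated step of a 1.8-fold higher number from compound 2 to compound 3 (0.24 log units; within the scatter). For compound 3, the estimated dose is 7 mg/kg, with an expected range from 2.5 mg/kg to 20 mg/kg.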

Compound 3, dose for half-maximal effect: 7 mg/kg
Estimate against measurement, compound 3: no gap at the digits printed, and the stated range covers the measured number.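

In this assay, carbamoyl in place of ethynyl on a saturated chain carbon bound to an aromatic nitrogen gives a 1.8-fold higher number from compound 2 to compound 3 (0.24 log units; within the scatter). Within the data shown here, this is the first step read at this position, and it shows that propargyl can give way to carbamoylmethyl, bringing in a hydrogen-bond donor and a hydrogen-bond acceptor, without a difference beyond the scatter in this assay. Compound 1 remains a limit and not a number, and it adds no step to this reading: the limit of > 10 mg/kg in this assay, at which 1 of the 3 values shown sits.

The compounds shown leave open whether an amine, a carboxylic acid or a longer chain at this same place would also stay within the scatter of compound 2. With a single step on one core, they also cannot say whether the exchange of ethynyl for carbamoyl would read the same way on any other core.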